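The source may hold more compounds than are shown below. What is called first, only, known or untested is meant among the compounds shown, and "the series" means these compounds.

Measured compounds:
compound 1, `Brc1ccccc1CSc1nnc(-c2ccncc2)n1-c1ccccc1`, 16100 nM
compound 2, `Brc1cccc(CSc2nnc(-c3ccncc3)n2-c2ccccc2)c1`, 10000 nM

Both compounds were tested in a functional assay on MCF7 cells (Homo sapiens) for inhibition, read by MTT assay, with a stated time of 48 h; a higher number here means a weaker inhibitor, a lower number a stronger inhibitor. Compound 1 gives 16100 nM and compound 2 gives 10000 nM. Among the measured compounds shown here, compound 2 has the lower of the two numbers, but the only step so far, a 1.6-fold lower number from compound 1 to compound 2 (0.21 log units; within the scatter), is within the scatter, so the two compounds cannot be ranked against each other.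

Compound 3, `Brc1ccc(CSc2nnc(-c3ccncc3)n2-c2ccccc2)cc1`, has not yet been measured. It differs from compound 2 by 4-bromophenyl in place of 3-bromophenyl on a saturated chain carbon bound to a sulfur. For the measured compounds named here, the one measured step that bears on this change is the move of the bromine around the same ring from compound 1 to compound 2, and that step, a 1.6-fold lower number from compound 1 to compound 2 (0.21 log units; within the scatter), did not exceed the scatter. On this basis no step beyond the scatter is expected in this assay for the further move of the bromine.

Compound 3 is therefore expected to give about 11000 nM in this assay, with a likely range of 4500 nM to 27000 nM. This estimate corresponds to an expected step of a 1.1-fold higher number from compound 2 to compound 3 (0.04 log units; within the scatter), essentially no change beyond the scatter.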

Compound 3, half-maximal inhibitory concentration: 12600 nM
Compound 3: the middle estimate sits 1.1-fold (0.06 log units) below what was measured; measured number inside the range.
By their numbers in this assay, from the lowest: compounds 2, 3 and 1 (each within the scatter of the next).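

Compound 3 completes the set of 2-bromophenyl, 3-bromophenyl and 4-bromophenyl on a saturated chain carbon bound to a sulfur, and neither new step in this assay (a 1.3-fold higher number from compound 2 to compound 3 (0.10 log units; within the scatter); a 1.3-fold lower number from compound 1 to compound 3 (0.11 log units; within the scatter)) lies beyond the scatter. Together with the earlier step between compound 1 and compound 2, this means that all three pairs among these compounds now lie within the scatter of each other, so the place of the bromine on this ring does not separate compound 1, compound 2 and compound 3 in this assay, whereas the earlier pair alone spoke for only a single move of the bromine. No measurement is available that would explain this lack of separation.

The compounds shown leave open whether anything other than bromine on this ring, such as a methoxy group, a nitrile or an amine, or the bare phenyl ring itself, would produce a step beyond the scatter. They also leave open whether a longer chain between the sulfur and the ring, or a carboxylic acid on the ring, would shift the number in this assay.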